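The source may report more compounds than this note shows. Statements on the series, on what has been measured and on what is new or still open speak of the compounds shown alone.

Among the measured compounds shown here, compound 2, `O=C(O)c1cc(-n2c(-c3ccc(Cl)cc3)cc3c2CCCC3)ccc1O`, is the only member of this small series with a plain number in a functional assay on the whole organism (strain Wistar) for inhibition, with Rattus norvegicus as the target, read by paw edema, with stated times of 30 min and 3 h, at a dose of 200 mg/kg by the oral route (a lower number here means less inhibition, a higher number more inhibition at the dose given (going by the name of the read-out)), where compound 2 gives 40%. Its partner compound 1, `O=C(O)c1cc(-n2c(-c3ccc(F)cc3)cc3c2CCCC3)ccc1O`, is reported in this assay only as a limit, >= 60%. The step measured so far, a number at least 20 percentage points lower from compound 1 to compound 2 (beyond the scatter), is the single one available, and it runs against the limit described in the limit of >= 60% in this assay, at which 1 of the 2 values shown sits. The unmeasured compound 3, `O=C(O)c1cc(-n2c(-c3ccc(O)cc3)cc3c2CCCC3)ccc1O`, changes a different group on the same position: hydroxy in place of chloro on an aromatic carbon. For the measured compounds named here, no measured step exchanges a halogen for a hydroxy group, so the chloro-for-fluoro step gives no direct guide to the direction of this change. Compound 3 is therefore expected to remain near the value of compound 2, with a step of no change at the digits printed from compound 2 to compound 3 (within the scatter), and its inhibition in this assay is estimated at 40%, within a range from 15% to 65%.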

Compound 3, a percentage reported as inhibition, in the whole organism at one dose (the size of the read-out at that dose, not a potency): 20%
Estimate against measurement, compound 3: 20 percentage points above; measured number inside the range.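

Hydroxy in place of chloro gives a number 20 percentage points lower from compound 2 to compound 3 (beyond the scatter), so this position responds to more than an exchange of one halogen for another, and the new group moves the number further in the direction already seen with chloro in place of fluoro. Hydroxy in place of fluoro gives a number at least 40 percentage points lower from compound 1 to compound 3 (beyond the scatter), the largest step at this position, and with every step beyond the scatter, the three compounds fall in the order fluoro, chloro, hydroxy in this assay. The top of that order, compound 1, is held only as a limit: the limit of >= 60% in this assay, at which 1 of the 3 values shown sits.

The compounds shown leave open how a methoxy group, an amine or a trifluoromethyl group on this aromatic carbon would read in this assay. They also leave open whether the same order would hold with the carboxylic acid of the shared core replaced by an amide.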